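Expected growth inhibition of a chloro analogue in DU-145 cells

The source may hold more compounds than are shown below. What is called first, only, known or untested is meant among the compounds shown, and "the series" means these compounds.

Three compounds were measured in a functional assay on DU-145 cells (Homo sapiens) for inhibition, read by trypan blue exclusion, with a stated time of 96 h; on this read-out lower numbers stand for stronger inhibition of growth and higher numbers for weaker inhibition of growth. Compound 1 `COc1ccccc1/C=C(/SCc1ccc(F)cc1)C(=O)c1ccc(Br)cc1` gives 10000 nM, compound 2 `Cc1ccsc1/C=C(/SCc1ccc(F)cc1)C(=O)c1ccc(Br)cc1` gives 50000 nM, and compound 3 `Cc1ccsc1/C=C(/SCc1ccc(Cl)cc1)C(=O)c1ccc(Br)cc1` gives 25000 nM. Compound 2 and compound 3 differ only by chloro in place of fluoro on an aromatic carbon, and the step is a 2.0-fold lower number from compound 2 to compound 3 (0.30 log units; within the scatter). Compound 2 and compound 1 differ by 2-methoxyphenyl in place of 3-methylthiophen-2-yl on a double-bonded chain carbon bound to a double-bonded chain carbon, and the step is a 5.0-fold lower number from compound 2 to compound 1 (0.70 log units; beyond the scatter). Compound 4 `COc1ccccc1/C=C(/SCc1ccc(Cl)cc1)C(=O)c1ccc(Br)cc1` is not yet measured; it differs from compound 3 by 2-methoxyphenyl in place of 3-methylthiophen-2-yl on a double-bonded chain carbon bound to a double-bonded chain carbon, the same change as from compound 2 to compound 1. For compound 4 the expected step in this assay is a 4.2-fold lower number from compound 3 to compound 4 (0.62 log units; beyond the scatter), of about the size seen in a 5.0-fold lower number from compound 2 to compound 1 (0.70 log units; beyond the scatter), because compound 3 sits at 25000 nM and compound 1 stands at 10000 nM within the scatter of where compound 4 is expected. Compound 4 is estimated at 6000 nM, between 2500 nM and 15000 nM.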

Compound 4, concentration for 50% growth inhibition: 1000 nM
Compound 4: the middle estimate sits 6.0-fold (0.78 log units) above what was measured; measured number outside the range, below it.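

In this assay, 2-methoxyphenyl in place of 3-methylthiophen-2-yl gives a 25-fold lower number from compound 3 to compound 4 (1.40 log units; beyond the scatter), so the change carries over between cores in direction but not in size: the same change on two cores in this assay, a 5.0-fold lower number (0.70 log units; beyond the scatter) from compound 2 to compound 1 and a 25-fold lower number (1.40 log units; beyond the scatter) from compound 3 to compound 4, 5.0-fold (0.70 log units) apart, beyond the scatter of two such steps. Chloro in place of fluoro gives a 10-fold lower number from compound 1 to compound 4 (1.00 log units; beyond the scatter), and its size also depends on the core: the same change on two cores in this assay, a 2.0-fold lower number (0.30 log units; within the scatter) from compound 2 to compound 3 and a 10-fold lower number (1.00 log units; beyond the scatter) from compound 1 to compound 4, 5.0-fold (0.70 log units) apart, beyond the scatter of two such steps. The two changes therefore do not add independently across these four compounds, but the data do not show why, nor whether this holds for any other pair of groups.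

The compounds shown leave open whether a nitrile or an amine in place of chloro on an aromatic carbon would behave the same way. They also leave open whether the pattern extends beyond these two groups on the double-bonded chain carbon, for example to an unsubstituted phenyl.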